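This account rests on a few compounds, and the source may have more. Where it says the series, first, only, none or still open, it means among the compounds named here.

Values measured in a physicochemical assay for lipophilicity, using the shake flask method; on this read-out higher numbers stand for higher lipophilicity and lower numbers for lower lipophilicity:

- Compound 1 `O=C(Nc1ccc(C(F)(F)F)cc1)NC1CCN(C(=O)C2CC2)CC1`: 3.18
- Compound 2 `CC(C)CC(=O)N1CCC(NC(=O)Nc2ccc(C(F)(F)F)cc2)CC1`: 3.86
- Compound 3 `CCC(C)C(=O)N1CCC(NC(=O)Nc2ccc(C(F)(C(F)(F)F)C(F)(F)F)cc2)CC1`: 4.96

Among these three, compound 2 holds the middle place at 3.86. In this assay, compound 1 lies lower at 3.18 and compound 3 lies higher at 4.96.

The next compound to be measured is compound 4 `CCCS(=O)(=O)N1CCC(NC(=O)Nc2ccc(C(F)(F)F)cc2)CC1`, which has not yet been tested. It carries propylsulfonyl in place of isobutylcarbonyl on an amine nitrogen in a ring.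

Among the compounds with values here, only one measured step bears on this change, and it bears on it indirectly. That step is a number 0.68 log units higher from compound 1 to compound 2 (beyond the scatter), with isobutyl in place of cyclopropyl on a carbonyl carbon. Compound 3 differs from compound 2 in more than one place, so it offers no clean comparison. Within the data shown here, no measured pair exchanges a carbonyl for a sulfonyl, which leaves the direction of the new step poorly defined. Among the measured compounds shown here, the change is therefore expected to be smaller than the one measured step, with a slight fall the more likely outcome.

The estimate is a number 0.16 log units lower from compound 2 to compound 4 (within the scatter), a step expected to stay within the scatter. For compound 4, the estimated value is 3.7, with an expected range from 3.2 to 4.2.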

Compound 4, partition coefficient: 3.39
The estimate for compound 4 lay 0.31 log units above the measured number; measured number inside the range.
By their numbers in this assay, from the lowest: compounds 1 and 4 (each within the scatter of the next); then compound 2; then compound 3.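

In this assay, the amine nitrogen in the ring now has a measured exchange of a carbonyl-linked group for a sulfonyl-linked one, and the outcome is a number 0.47 log units lower from compound 2 to compound 4 (beyond the scatter). The exchange keeps the count of 6 heavy atoms but swaps carbon for sulfur and oxygen, and the second comparison at this position, a number 0.21 log units higher from compound 1 to compound 4 (within the scatter), shows that propylsulfonyl and cyclopropylcarbonyl cannot be told apart on this read-out, so the size of a step here depends on which acyl group is being replaced. No independent measurement bears on why the number moves as it does at this position.

Both steps change the linking group and the carbon chain together, so the share of the sulfonyl itself remains unresolved: propylcarbonyl on the same nitrogen would separate it from the propyl chain, and isobutylsulfonyl or cyclopropylsulfonyl would give the direct partners of compound 2 and compound 1. On these data alone, it also remains open whether a step of this kind would hold on a core carrying a group other than trifluoromethyl, such as a chlorine or a nitrile.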